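Sulfonyl substituent change from compound 2 to compound 3

This account rests on a few compounds, and the source may have more. Where it says the series, first, only, none or still open, it means among the compounds named here.

Measured so far:
compound 1 `N#C/N=C(\NCc1ccc(S(=O)(=O)c2cccc(C(F)(F)F)c2)cc1)Nc1ccncc1`: 2.9 nM
compound 2 `N#C/N=C(\NCc1ccc(S(=O)(=O)N2CC3CCC(C2)O3)cc1)Nc1ccncc1`: 50 nM

In a functional assay on A2780 cells (Homo sapiens) for antiproliferative activity, read by sulforhodamine B assay, with a stated time of 72 h (on this read-out lower numbers stand for stronger inhibition and higher numbers for weaker inhibition), compound 2 gives 50 nM, the highest of the two numbers; compound 1 gives 2.9 nM. Going by the values given here, the one measured step, a 17-fold higher number from compound 1 to compound 2 (1.24 log units; beyond the scatter), is the only comparison that bears on the next change. Compound 3 `N#C/N=C(\NCc1ccc(S(=O)(=O)C2CCCCC2)cc1)Nc1ccncc1` carries a group of 6 heavy atoms (6 carbon; one six-membered non-aromatic ring of carbon only) in place of a group of 8 heavy atoms (6 carbon, 1 nitrogen, 1 oxygen; one five-membered non-aromatic ring with 1 hetero atom, one six-membered non-aromatic ring with 2 hetero atoms), on a sulfonyl sulfur. The entering group is, as in compound 1, a six-membered ring of carbon only with no hydrogen-bond acceptor, so part of the loss in a 17-fold higher number from compound 1 to compound 2 (1.24 log units; beyond the scatter) is expected to be reversed. Compound 3 is estimated at 12 nM, within 3 nM to 45 nM. The expected step is a 4.2-fold lower number from compound 2 to compound 3 (0.62 log units; beyond the scatter).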

Compound 3, half-maximal inhibitory concentration: 14.8 nM
The estimate for compound 3 lay 1.2-fold (0.09 log units) below the measured number; measured number inside the range.
By their numbers in this assay, from the lowest: compound 1; then compound 3; then compound 2.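

On the sulfonyl sulfur, cyclohexyl recovers part of the loss seen with the group in compound 2 in this assay (a 3.4-fold lower number from compound 2 to compound 3 (0.53 log units; beyond the scatter)). It does not reach the level of 3-(trifluoromethyl)phenyl (a 5.1-fold higher number from compound 1 to compound 3 (0.71 log units; beyond the scatter)), so a six-membered ring of carbon only does not match that group at this place. Nothing available explains either step.

Going by these compounds, it remains open whether the remaining gap follows the aromatic ring or the trifluoromethyl group. Unsubstituted phenyl on the sulfonyl sulfur would separate the two.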